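A Smaller Group on the Carbonyl Carbon

The source may hold more compounds than are shown below. What is called first, only, known or untested is meant among the compounds shown, and "the series" means these compounds.

Going by the values given here, compound 2 `O=C(c1ccccc1C(F)(F)F)N(/N=N/c1ccc([N+](=O)[O-])cc1Cl)c1ccc([N+](=O)[O-])cc1Cl` gives 10600 nM in a functional assay on HeLa cells (Homo sapiens) for cytotoxicity, read by MTT assay, with a stated time of 72 h (a higher number here means a weaker inhibitor, a lower number a stronger inhibitor), the higher of the two numbers measured so far; compound 1 `O=C(c1ccccc1)N(/N=N/c1ccc([N+](=O)[O-])cc1Cl)c1ccc([N+](=O)[O-])cc1Cl` gives 590 nM. Among the compounds with values here, the only measured step, an 18-fold higher number from compound 1 to compound 2 (1.25 log units; beyond the scatter), came from trifluoromethyl in place of hydrogen on an aromatic carbon. Compound 3 `O=C(CCl)N(/N=N/c1ccc([N+](=O)[O-])cc1Cl)c1ccc([N+](=O)[O-])cc1Cl` differs from compound 2 by chloromethyl in place of 2-(trifluoromethyl)phenyl on a carbonyl carbon. Within the data shown here, this change removes the trifluoromethyl together with its whole ring, so it is not the reverse of the measured step, and no measured step covers it directly. The number for compound 3 is nevertheless expected to drop, by about a 5.3-fold lower number from compound 2 to compound 3 (0.72 log units; beyond the scatter), with wide uncertainty. The estimate for compound 3 is 2000 nM, between 300 nM and 15000 nM.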

Compound 3, half-maximal inhibitory concentration: 550 nM
Estimate against measurement, compound 3: 3.6-fold (0.56 log units) above; measured number inside the range.
By their numbers in this assay, from the lowest: compounds 3 and 1 (each within the scatter of the next); then compound 2.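

On the carbonyl carbon, chloromethyl gives a 19-fold lower number from compound 2 to compound 3 (1.28 log units; beyond the scatter) and so removes the large penalty seen with 2-(trifluoromethyl)phenyl. The exchange for plain phenyl gives a 1.1-fold lower number from compound 1 to compound 3 (0.03 log units; within the scatter) in this assay and so shows that a ring on this carbon is not needed to keep the number of compound 1. Nothing available explains either result.

As far as these compounds go, whether the chlorine matters remains open, since plain methyl would test that directly. A longer chain, such as 3-chloropropyl, or an amine such as aminomethyl could also show how much change this position tolerates.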